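The source may report more compounds than this note shows. Statements on the series, on what has been measured and on what is new or still open speak of the compounds shown alone.

Measured compounds in a functional assay on MCF7 cells (Homo sapiens) for inhibition, read by MTT assay, with a stated time of 72 h; a lower number here means a stronger inhibitor, a higher number a weaker inhibitor:
compound 1 `Cc1ccc(-n2cc(CSC(=S)N3CCN(C(=O)OC(C)(C)C)CC3)nn2)cc1`, 74200 nM
compound 3 `Cc1ccc(Cn2cc(CSC(=S)N3CCN(C(=O)OCc4ccccc4)CC3)nn2)cc1`, 37800 nM
compound 2 `S=C(SCc1cn(Cc2ccc(Cl)cc2)nn1)N1CCNCC1`, "not determined" (no result reported)

Compound 1 carries the higher of the two numbers in this assay, but its gap to compound 3 lies within the scatter, so the two cannot be told apart on these data. Compound 2 contributes no number. Compound 4 `CC(C)(C)OC(=O)N1CCN(C(=S)SCc2cn(Cc3ccccc3Cl)nn2)CC1` has not yet been measured in this assay. Against compound 1 the change is 2-chlorobenzyl in place of 4-methylphenyl on an aromatic nitrogen. Within the data shown here, no step between measured compounds covers this change, and the one comparison present, compound 1 against compound 3, shows nothing beyond the scatter. The step from compound 1 to compound 4 is expected to be a 1.3-fold lower number from compound 1 to compound 4 (0.13 log units; within the scatter), none beyond the scatter. Compound 4 is estimated at 55000 nM, in the range 20000 nM to 150000 nM.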

Compound 4, half-maximal inhibitory concentration: 6090 nM
Compound 4: middle estimate off by 9.0-fold (0.96 log units), on the high side; measured number below the stated range.
By their numbers in this assay, from the lowest: compound 4; then compounds 3 and 1 (each within the scatter of the next).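

In this assay the group on the aromatic nitrogen of the five-membered ring proves able to shift the number: 2-chlorobenzyl in place of 4-methylphenyl gives a large step (a 12-fold lower number from compound 1 to compound 4 (1.09 log units; beyond the scatter)). Among these compounds, the earlier compounds showed no separation beyond the scatter, so this is the first change with a clear effect. Nothing available accounts for this step. The compounds shown leave open whether the step belongs to the benzyl attachment or to the chlorine. A plain benzyl group at this position would separate the two.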